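A few compounds are considered here, and "the series" means these few. Any claim that something is new, unique, unknown or untested is made for them only; others in the source may bear on it.

Compound 1 `C=C1C(=O)OC[C@@H]1CCOC(=O)Nc1ccc(C(C)C)cc1` is measured in an ADME assay on RAW264.7 cells (Mus musculus) for cytotoxicity, read by MTT assay, with a stated time of 18 h (on this read-out lower numbers stand for higher toxicity in this test and higher numbers for lower toxicity in this test), at 15300 nM. Compound 2 `C=C1C(=O)OC[C@@H]1CCOC(=O)Nc1ccc(CC)cc1` gives 7580 nM in this assay, and compound 3 `C=C1C(=O)OC[C@H]1CCOC(=O)Nc1ccc(C(C)C)cc1` gives 12400 nM in this assay.

Two single changes connect these three. From compound 1 to compound 2 the change is hydrogen in place of methyl on a saturated chain carbon bound to an aromatic carbon and a saturated chain carbon, and it brings a 2.0-fold lower number from compound 1 to compound 2 (0.31 log units; beyond the scatter). From compound 1 to compound 3 the cores differ only in this way: the two compounds have the same atoms and bonds and differ only in configuration as drawn: 1 of 1 stereo elements differ; a stereocentre at a saturated ring carbon is drawn R in compound 1 and S in compound 3. The accompanying step is a 1.2-fold lower number from compound 1 to compound 3 (0.09 log units; within the scatter), which rests on the fact that compounds 1 and 3 differ only in the configuration as drawn and stays inside the usual spread of repeats, so no ordering of compound 1 against compound 3 is drawn from it.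

Compound 4 `C=C1C(=O)OC[C@H]1CCOC(=O)Nc1ccc(CC)cc1` has not yet been measured in this assay. It stands to compound 3 as compound 2 stands to compound 1: the change is hydrogen in place of methyl on a saturated chain carbon bound to an aromatic carbon and a saturated chain carbon, the same change as before, made on the core of compound 3 instead of the core of compound 1. Among the compounds with values here, the expected step is a 2.0-fold lower number from compound 3 to compound 4 (0.30 log units; within the scatter), estimated from the single measured instance, because a 2.0-fold lower number from compound 1 to compound 2 (0.31 log units; beyond the scatter) is the only precedent and the two cores gave a 1.2-fold lower number from compound 1 to compound 3 (0.09 log units; within the scatter) within the scatter. On that basis compound 4 is expected to read about 6200 nM, with a plausible range of 3500 nM to 11000 nM.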

Compound 4, half-maximal cytotoxic concentration: 11400 nM
Compound 4: the middle estimate sits 1.8-fold (0.26 log units) below what was measured, and the stated range ends below it.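

In this assay, isopropyl to ethyl on the core of compound 3 gives a 1.1-fold lower number from compound 3 to compound 4 (0.04 log units; within the scatter), and the two instances of this change cannot be told apart: the same change on two cores in this assay, a 2.0-fold lower number (0.31 log units; beyond the scatter) from compound 1 to compound 2 and a 1.1-fold lower number (0.04 log units; within the scatter) from compound 3 to compound 4, 1.9-fold (0.27 log units) apart, within the scatter of two such steps. The pair with the opposite drawn configuration gives a 1.5-fold higher number from compound 2 to compound 4 (0.18 log units; within the scatter), so no ordering of compound 2 against compound 4 can be drawn: the fact that compounds 2 and 4 differ only in the configuration as drawn. Within these four compounds, the change therefore carries from one core to the other without a resolved dependence on the core, but this does not show that the step has the same size on both, and with one pair per core it gives no general rule for the series.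

From the compounds shown here alone, it remains open whether a longer chain, an amine or a carboxylic acid in the same place would behave alike on the two cores. A wider set of such groups on both cores would show whether any dependence on configuration appears beyond the isopropyl and ethyl pairs.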